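Trifluoromethyl for tert-butyl in a pair of cytotoxic compounds

A few compounds are considered here, and "the series" means these few. Any claim that something is new, unique, unknown or untested is made for them only; others in the source may bear on it.

Compound 1 `COc1ccc(/C=C2\CN(C)C/C(=C\c3ccccc3F)C2=O)cc1`: 15400 nM
Compound 2 `CN1C/C(=C\c2ccc(C(C)(C)C)cc2)C(=O)/C(=C/c2ccccc2F)C1`: 13400 nM

In a functional assay on THP-1 cells (Homo sapiens) for cytotoxicity, read by MTT assay, with a stated time of 24 h (a higher number here means a weaker inhibitor, a lower number a stronger inhibitor), compound 2 gives 13400 nM, level with compound 1 within the scatter. Compound 3 `CN1C/C(=C\c2ccc(C(F)(F)F)cc2)C(=O)/C(=C/c2ccccc2F)C1` carries trifluoromethyl in place of tert-butyl on an aromatic carbon. Among the measured compounds shown here, only one measured step bears on this, with tert-butyl in place of methoxy on an aromatic carbon: a 1.1-fold lower number from compound 1 to compound 2 (0.06 log units; within the scatter). For the measured compounds named here, that step lies within the scatter, and no trifluoromethyl compound has been measured yet, so this single step is thin evidence. No step beyond the scatter is expected in this assay. The expected step is a 1.1-fold lower number from compound 2 to compound 3 (0.05 log units; within the scatter). For compound 3 the estimate is 12000 nM, with an expected range of 6000 nM to 24000 nM.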

Compound 3, half-maximal inhibitory concentration: 5930 nM
Estimate against measurement, compound 3: 2.0-fold (0.31 log units) above, and the stated range ends above it.
By their numbers in this assay, from the lowest: compound 3; then compounds 2 and 1 (each within the scatter of the next).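

Methoxy and tert-butyl at this position gave numbers level within the scatter in this assay, which could have suggested that the group there hardly matters. Trifluoromethyl is the first group to shift the reading, with a 2.3-fold lower number from compound 2 to compound 3 (0.35 log units; beyond the scatter) and a 2.6-fold lower number from compound 1 to compound 3 (0.41 log units; beyond the scatter) as modest steps, so the position does respond to what it carries. Nothing measured here explains why this group stands apart from the other two.

Going by these compounds, whether an amine or a carboxylic acid at this position would lower the number further remains open. So does whether trifluoromethyl would give a similar step with a different group on the other aromatic ring.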